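Replacing tert-butoxycarbonyl with methylsulfonyl on a pentyl linker

The compounds below may be only part of what the source reports. "The series", "measured", "known", "first", "only" and "open" are said of these compounds alone.

Measured compounds:
compound 1 `CC(C)(C)OC(=O)NCCCCCNC(=O)CN1CN(c2ccccc2)C2(CCN(C(=O)c3ccc(C(C)(C)C)cc3)CC2)C1=O` 13700 nM
compound 2 `CC(C)(C)OC(=O)NCCCCNC(=O)CN1CN(c2ccccc2)C2(CCN(C(=O)c3ccc(C4CCCCC4)cc3)CC2)C1=O` 4600 nM
compound 3 `CS(=O)(=O)NCCCNC(=O)CN1CN(c2ccccc2)C2(CCN(C(=O)c3ccc(C4CCCCC4)cc3)CC2)C1=O` 3800 nM

In an assay on HEK293 cells for displacement of a labelled ligand from NPC1-like intracellular cholesterol transporter 1 (Homo sapiens) (a higher number here means a weaker inhibitor, a lower number a stronger inhibitor), compound 1 gives the highest number of the three, with compound 2 nearer to it and compound 3 furthest from it. The new compound 4 `CC(C)(C)c1ccc(C(=O)N2CCC3(CC2)C(=O)N(CC(=O)NCCCCCNS(C)(=O)=O)CN3c2ccccc2)cc1` differs from compound 1 as follows: methylsulfonyl in place of tert-butoxycarbonyl on an amine nitrogen. Among the measured compounds shown here, the one measured step that bears on this is a 1.2-fold lower number from compound 2 to compound 3 (0.08 log units; within the scatter), a change at the same chain end that moved the number hardly at all. The author therefore expects no step beyond the scatter in this assay, so that a 1.1-fold lower number from compound 1 to compound 4 (0.06 log units; within the scatter) is estimated. Compound 4 is expected to give about 12000 nM, with a range from 5000 nM to 28000 nM.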

Compound 4, half-maximal inhibitory concentration: 5500 nM
Estimate against measurement, compound 4: 2.2-fold (0.34 log units) above; measured number inside the range.
By their numbers in this assay, from the lowest: compounds 3, 2 and 4 (each within the scatter of the next); then compound 1.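

In this assay, methylsulfonyl in place of tert-butoxycarbonyl on an amine nitrogen of the pentyl chain gives a change beyond the scatter (a 2.5-fold lower number from compound 1 to compound 4 (0.40 log units; beyond the scatter)), so this chain end can affect the number. The earlier step at the same chain end stayed within the scatter (a 1.2-fold lower number from compound 2 to compound 3 (0.08 log units; within the scatter)), so the swap does not behave alike in both pairs. No evidence here explains why the two steps differ. The compounds shown leave open how a free amine or an acetyl group on that nitrogen would compare. They also leave open whether a longer chain carrying methylsulfonyl would give a lower number still.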